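The source may report more compounds than this note shows. Statements on the series, on what has been measured and on what is new or still open speak of the compounds shown alone.

Compound 1 `COc1ccc(NC(=O)N[C@H]2CC[C@H](Oc3ccc(F)cc3)CC2)cc1` was tested in a functional assay on CRL2813 cells (Homo sapiens) for cytotoxicity, read by sulforhodamine B assay, with a stated time of 5 days; on this read-out lower numbers stand for stronger inhibition and higher numbers for weaker inhibition. In this assay compound 1 gives > 20000 nM, which is a limit of the assay rather than a measured number. Compound 2 `O=C(Nc1ccccc1C(=O)O)N[C@H]1CC[C@@H](Oc2ccc(F)cc2)CC1` likewise gives > 20000 nM in this assay, again only a limit. Compound 3 `O=C(Nc1cccc(C(F)(F)F)c1)N[C@H]1CC[C@H](Oc2ccc(C(F)(F)F)cc2)CC1` gives 460 nM in this assay. Compound 1 therefore stands at the limit of > 20000 nM in this assay, at which 2 of the 3 values shown sit. Compound 4 `CSc1cccc(NC(=O)N[C@H]2CC[C@H](Oc3ccc(F)cc3)CC2)c1` differs from compound 1 in one place: 3-(methylsulfanyl)phenyl in place of 4-methoxyphenyl on an amide-type nitrogen. Among the compounds with values here, no two measured compounds differ in only one place, so the size of such a step cannot be read from the values shown. The step is expected to be an at least 2.5-fold lower number from compound 1 to compound 4 (0.39 log units; beyond the scatter), toward stronger inhibition, though it may stay within the scatter. Compound 4 is accordingly estimated at 8000 nM, between 2000 nM and 20000 nM.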

Compound 4, half-maximal inhibitory concentration: 11100 nM
For compound 4 the middle estimate is 1.4-fold (0.14 log units) below the measured one; low and high end bracket the measured number.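

Within the data shown here, the swap of 4-methoxyphenyl for 3-(methylsulfanyl)phenyl on the amide-type nitrogen is the first single change seen here, and in this assay it gives an at least 1.8-fold lower number from compound 1 to compound 4 (0.25 log units; that floor lies within the scatter). That floor alone does not establish a real change at this position. The full size of the step cannot be read because compound 1 gives only a limit: the limit of > 20000 nM in this assay, at which 2 of the 4 values shown sit.

The compounds shown do not separate the exchange of oxygen for sulfur from the change in where the group sits on the ring. Neither 3-methoxyphenyl nor 4-(methylsulfanyl)phenyl appears on this nitrogen among them.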